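The source may hold more compounds than are shown below. What is called first, only, known or untested is meant among the compounds shown, and "the series" means these compounds.

In a functional assay (Nicotiana tabacum) (on this read-out lower numbers stand for stronger inhibition and higher numbers for weaker inhibition), compound 3 (`CCCCC(CC)CNc1nc(SC)nc2ncccc12`) gives 15900 nM as the highest of the three numbers, ahead of compound 2 (`CCC(C)Nc1nc(SC)nc2ncccc12`) at 860 nM and compound 1 (`CCCCNc1nc(SC)nc2ncccc12`) at 270 nM on the same shared core. The change to compound 4 (`COCCNc1nc(SC)nc2ncccc12`) is methoxymethyl in place of 1-ethylpentyl on a saturated chain carbon bound to a nitrogen on an aromatic ring. For the measured compounds named here, two measured steps bear on it. The larger is a 59-fold higher number from compound 1 to compound 3 (1.77 log units; beyond the scatter) and it leads to the group that now leaves. The smaller is a 3.2-fold higher number from compound 1 to compound 2 (0.50 log units; beyond the scatter) and it comes with sec-butyl in place of butyl. The chain of compound 4 is unbranched, as is that of compound 1, so most of the large step should be undone. Going by the values given here, no measured compound carries the oxygen of methoxymethyl, so a full return is not assumed. A large step to a lower number is expected in this assay and a 23-fold lower number from compound 3 to compound 4 (1.36 log units; beyond the scatter) is the estimated size of it. The expected value for compound 4 is 700 nM (estimated range 200 nM to 2800 nM).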

Compound 4, half-maximal inhibitory concentration: 2530 nM
Compound 4: the middle estimate sits 3.6-fold (0.56 log units) below what was measured; the measured number falls inside the stated range.
By their numbers in this assay, from the lowest: compound 1; then compound 2; then compound 4; then compound 3.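

In this assay, replacing 1-ethylpentyl with methoxymethyl recovers only part of the loss seen with the large branched chain: a 6.3-fold lower number from compound 3 to compound 4 (0.80 log units; beyond the scatter). An unbranched chain is therefore not enough to restore the number of compound 1, since methoxy in place of ethyl on a saturated chain carbon, two bonds along the chain from a nitrogen on an aromatic ring, gives a 9.4-fold higher number from compound 1 to compound 4 (0.97 log units; beyond the scatter). Branching alone does not set the order either, as 2-methoxyethyl in place of sec-butyl gives a 2.9-fold higher number from compound 2 to compound 4 (0.47 log units; beyond the scatter), leaving the unbranched compound 4 above the branched compound 2.

Nothing available explains why the oxygen-bearing chain gives the higher number. On these data alone, it remains open whether a hydroxyl or an amine in that place would track methoxy, and whether a longer unbranched carbon chain would hold the number of compound 1.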